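This account rests on a few compounds, and the source may have more. Where it says the series, first, only, none or still open, it means among the compounds named here.

Compound 1, `CC(=O)N1CC[C@@H](C(=O)N(C)Cc2cc(C(F)(F)F)cc(C(F)(F)F)c2)[C@H](c2ccccc2)C1`, is the simplest of the three measured compounds; in an assay on IM-9 cells for displacement of a labelled ligand from Substance-P receptor (Homo sapiens), read by scintillation counting, with a stated time of 30 min (on this read-out lower numbers stand for stronger inhibition and higher numbers for weaker inhibition), compound 1 gives 2.6 nM. Compound 2, `CC(=O)N1CCC(C(=O)N2CC[C@@H](C(=O)N(C)Cc3cc(C(F)(F)F)cc(C(F)(F)F)c3)[C@H](c3ccccc3)C2)CC1`, carries a 1-acetylpiperidin-4-yl group on the carbonyl carbon where compound 1 has a methyl, and in this assay compound 2 gives 0.098 nM. This single change gave a 27-fold lower number from compound 1 to compound 2 (1.42 log units; beyond the scatter). Compound 3, `CCc1ccccc1[C@H]1CN(C(=O)C2CCN(C(C)=O)CC2)CC[C@@H]1C(=O)N(C)Cc1cc(C(F)(F)F)cc(C(F)(F)F)c1`, adds an ethyl group to the phenyl ring of that same core; in this assay compound 3 gives 0.064 nM, the lowest of the three numbers shown, though compound 2 sits within the usual scatter of it, while compound 1 lies well beyond.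

Compound 4, `CC(=O)N1CCC(C(=O)N2CC[C@H](C(=O)N(C)Cc3cc(C(F)(F)F)cc(C(F)(F)F)c3)[C@@H](c3ccccc3C(C)C)C2)CC1`, differs from compound 3 by methyl in place of hydrogen on a saturated chain carbon bound to an aromatic carbon and a saturated chain carbon. For the measured compounds named here, no measured pair covers this change. Going by the values given here, the only step that has been measured, the one from compound 1 to compound 2, concerns a different place in the molecule and says nothing about what a methyl on the ethyl side chain does. What the values of compound 2 and compound 3 show is that adding an ethyl to the phenyl ring left the number within the scatter. On that basis compound 4 is expected to stay close to compound 3, with a 1.3-fold higher number from compound 3 to compound 4 (0.10 log units; within the scatter) estimated as no step beyond the scatter. The estimate for compound 4 in this assay is therefore 0.08 nM, expected to fall between 0.03 nM and 0.25 nM.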

Compound 4, half-maximal inhibitory concentration: 0.21 nM
For compound 4 the middle estimate is 2.6-fold (0.42 log units) below the measured one, and the stated range covers the measured number.
By their numbers in this assay, from the lowest: compounds 3 and 2 (each within the scatter of the next); then compound 4; then compound 1.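

Replacing ethyl with isopropyl, which turns 2-ethylphenyl into 2-isopropylphenyl, gives a 3.3-fold higher number from compound 3 to compound 4 (0.52 log units; beyond the scatter) in this assay, so a single added methyl on this saturated chain carbon is enough to move the number beyond the scatter, though only modestly. For the compounds shown here, the earlier compounds could not show this: compound 2, which carries an unsubstituted phenyl, gives 0.098 nM and compound 3 gives 0.064 nM, two values within the scatter of each other, so the group on the phenyl ring had so far appeared to leave the number unchanged. No measurement is available that accounts for the step at this position.

The compounds shown leave open whether the number keeps rising with a tert-butyl or a longer chain such as n-propyl in place of the isopropyl, and how a cyclopropyl, a methoxy group or a chlorine atom would compare there. They also leave open whether ethyl to isopropyl would give a step of similar size on the core of compound 1, which has a methyl on the carbonyl carbon rather than the 1-acetylpiperidin-4-yl group.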